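This account rests on a few compounds, and the source may have more. Where it says the series, first, only, none or still open, it means among the compounds named here.

Measured compounds:
compound 1, `CC(=O)Nc1cccc(-c2ccc(C(=O)N(Cc3cccc(OCCCCCC(=O)O)c3)C(C)C)cc2)c1`, in this assay gives > 26000 nM
compound 2, `CCOC(=O)CCCCCOc1cccc(CN(C(=O)c2ccc(-c3cccc(NC(C)=O)c3)cc2)C(C)C)c1`, in this assay gives > 26000 nM
compound 3, `CCOC(=O)CCCCCOc1cccc(CN(C(=O)c2ccc(-c3cnc(OC)nc3OC)cc2)C(C)C)c1`, in this assay gives > 26000 nM

In an ADME assay on BJ cells (Homo sapiens) for cytotoxicity, read by CellTiter-Glo and resazurin assay, with a stated time of 72 h (on this read-out lower numbers stand for an effect already at smaller amounts and higher numbers for an effect only at larger amounts of compound), compound 2 gives > 26000 nM, which is a limit of the measurement and not a number. The other two measured compounds also stop at a limit, so all three sit at the limit of > 26000 nM in this assay, at which 3 of the 3 values shown sit. For this reason the two measured steps that touch compound 2 cannot be read: a step that the two limits leave unreadable from compound 1 to compound 2 and a step that the two limits leave unreadable from compound 2 to compound 3. Neither tells whether a change at the ester end or at the aromatic group alters cytotoxicity, and the values give no order among the three compounds.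

Compound 4, `CCOC(=O)CCCCCOc1cccc(CN(C(=O)c2ccc(-c3cccc(Oc4ccccc4)c3)cc2)C(C)C)c1`, is not yet measured. It differs from compound 2 in one place: phenoxy in place of acetamido on an aromatic carbon. For the measured compounds named here, no measured step reads on this exchange, and the two unreadable steps only show that other changes of the shared core left every compound at the limit. The step from compound 2 to compound 4 in this assay is therefore expected to be a step that the limit leaves unreadable from compound 2 to compound 4, meaning no change that can be read. Compound 4 is estimated at 30000 nM, within 12000 nM to 80000 nM, most likely again reported as a limit.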

Compound 4, half-maximal effective concentration: > 19600 nM
Compound 4 gave a limit, no number; the forecaster's own chance of this, stated with the estimate: 80%; the middle value is on the limit's open side.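

In this assay compound 4 gives > 19600 nM, which is a limit of the measurement and not a number. Compound 2 also stops at a limit, so the step between compound 2 and compound 4 cannot be read. The compounds shown leave open at what amount any of them has an effect, and whether they differ at all.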